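The compounds below may be only part of what the source reports. "The series", "measured", "known", "first", "only" and "open" are said of these compounds alone.

Of the compounds shown here, three sharing one core have been measured in a functional assay for agonist activity at G protein-coupled receptor 88 (Homo sapiens), read by HTRF and cAMP accumulation; on this read-out higher numbers stand for an effect only at larger amounts of compound and lower numbers for an effect already at smaller amounts. Compound 1 `CC(C)C[C@H](N)CN(C(=O)[C@@H]1C[C@H]1c1ccccc1)c1ccc(-c2ccoc2)cc1` gives 2000 nM. Compound 2 `Cc1cccc(-c2ccc(N(C[C@@H](N)CC(C)C)C(=O)[C@@H]3C[C@H]3c3ccccc3)cc2)c1` gives 1200 nM. Compound 3 `Cc1ccccc1-c1ccc(N(C[C@@H](N)CC(C)C)C(=O)[C@@H]2C[C@H]2c2ccccc2)cc1` gives 3400 nM, the highest of the three numbers; its gap to compound 1 is within the scatter, while the step of a 2.8-fold higher number from compound 2 to compound 3 (0.45 log units; beyond the scatter) lies beyond it. The two steps starting from compound 1, a 1.7-fold lower number from compound 1 to compound 2 (0.22 log units; within the scatter) and a 1.7-fold higher number from compound 1 to compound 3 (0.23 log units; within the scatter), both stay within the scatter.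

Compound 4 `CC(C)C[C@H](N)CN(C(=O)[C@@H]1C[C@H]1c1ccccc1)c1ccc(-c2cccc(F)c2)cc1` differs from compound 3 in one place: 3-fluorophenyl in place of 2-methylphenyl on an aromatic carbon. The entering 3-fluorophenyl is the closer relative of the 3-methylphenyl found in compound 2, so the step that bears most on this change is a 2.8-fold higher number from compound 2 to compound 3 (0.45 log units; beyond the scatter), read in reverse, with fluorine standing in for methyl. Only a modest lowering is therefore expected, and because of a 1.7-fold higher number from compound 1 to compound 3 (0.23 log units; within the scatter) the number should land near the others rather than far below them. Compound 4 is estimated to give 1500 nM, with a likely range from 600 nM to 4000 nM. For compound 4 this estimate amounts to a 2.3-fold lower number from compound 3 to compound 4 (0.36 log units; beyond the scatter).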

Compound 4, half-maximal effective concentration: 2100 nM
Compound 4: middle estimate off by 1.4-fold (0.15 log units), on the low side, and the stated range covers the measured number.
By their numbers in this assay, from the lowest: compounds 2, 1, 4 and 3 (each within the scatter of the next, the first and the last beyond it).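

Putting fluoro in place of methyl at the same spot on the outer ring gives a 1.8-fold higher number from compound 2 to compound 4 (0.24 log units; within the scatter), and the swap from 2-methylphenyl to 3-fluorophenyl gives a 1.6-fold lower number from compound 3 to compound 4 (0.21 log units; within the scatter), so compound 4 cannot be told apart from either end of the one gap beyond the scatter in this set. A six-membered carbon ring carrying fluorine also cannot be separated from the furan-3-yl group, with a 1.1-fold higher number from compound 1 to compound 4 (0.02 log units; within the scatter), which means that all four groups at this position fall in a narrow band of numbers. Nothing available here explains these small differences. Going by these compounds, it remains open whether a plain phenyl, a methoxy group or a carboxylic acid at this position would move the number beyond the scatter. On these data alone, how far changes elsewhere on the shared core, such as to the amine chain, would shift the number also remains open.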